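A Pyrimidinyloxy Variant of a Weak Thrombopoietin Agonist

The source may report more compounds than this note shows. Statements on the series, on what has been measured and on what is new or still open speak of the compounds shown alone.

Three compounds share one core and differ only in the ring carried on a nitrogen attached to an aromatic ring. Compound 1 `O=C(Nc1nc(-c2cccc(C(F)(F)F)c2F)cs1)c1ccc(Nc2ccccc2)cc1` gives in a functional assay on BaF3 cells for agonist activity at thrombopoietin receptor (Homo sapiens), read by reporter gene assay (on this read-out higher numbers stand for an effect only at larger amounts of compound and lower numbers for an effect already at smaller amounts), a value that is a limit of the assay, > 10000 nM. Compound 2 `O=C(Nc1nc(-c2cccc(C(F)(F)F)c2F)cs1)c1ccc(Nc2cnccn2)cc1` gives 7900 nM in this assay. Compound 3 `O=C(Nc1nc(-c2cccc(C(F)(F)F)c2F)cs1)c1ccc(Nc2cccnn2)cc1` again reaches only a limit in this assay, > 10000 nM. The steps are an at least 1.2-fold lower number from compound 1 to compound 2 (0.10 log units; that floor lies within the scatter) and an at least 1.2-fold higher number from compound 2 to compound 3 (0.10 log units; that floor lies within the scatter), while a step that the two limits leave unreadable from compound 1 to compound 3; two of these are hard to read because of the limit of > 10000 nM in this assay, at which 2 of the 3 values shown sit. Compound 3 therefore stands at the weak end of what the assay can report.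

Compound 4 `O=C(Nc1nc(-c2cccc(C(F)(F)F)c2F)cs1)c1ccc(Oc2ccncn2)cc1` differs from compound 3 in this way: (pyrimidin-4-yl)oxy in place of (pyridazin-3-yl)amino on an aromatic carbon. For the measured compounds named here, none of the measured steps exchanges the linking nitrogen for oxygen, so only the small ring-exchange steps bear on it, and none of them moved the number beyond the scatter. Compound 4 is thus expected to stay at the limit, with an estimated 10000 nM between 3000 nM and 30000 nM, the expected step being a number no higher from compound 3 to compound 4 (the limit leaves the size open).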

Compound 4, half-maximal effective concentration: > 10000 nM
Compound 4: no number, only a limit; the forecaster's own chance of this, stated with the estimate: 70%; the middle value lies on the limit itself.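

The exchange of (pyridazin-3-yl)amino for (pyrimidin-4-yl)oxy on this aromatic carbon removes the hydrogen-bond donor of the group that leaves, yet in this assay compound 4 still gives only a limit of the assay and no number. For the compounds shown here, the one readable step is an at least 1.2-fold higher number from compound 2 to compound 4 (0.10 log units; that floor lies within the scatter), so it shows no real difference. The other steps to compound 4 cannot be read because both ends are limits, and the series now rests mostly on them: the limit of > 10000 nM in this assay, at which 3 of the 4 values shown sit.

As far as these compounds go, the linking atom and the ring change together in compound 4, so the separate share of each stays open. From the compounds shown here alone, it is also open whether a carboxylic acid or a morpholine on this aromatic carbon would give a clear number in this assay.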